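Changing the Group on a Sulfonyl Sulfur

The compounds below may be only part of what the source reports. "The series", "measured", "known", "first", "only" and "open" are said of these compounds alone.

In a physicochemical assay for solubility, in phosphate buffer, with a stated time of 24 h, at pH 7.4, tested at 100 uM (a lower number here means a less soluble compound, a higher number a more soluble compound), compound 3 `O=C(NCc1ccc(S(=O)(=O)c2cccc(C(F)(F)F)c2)cc1)N1Cc2ccncc2C1` gives 10000 nM, and compound 1 `O=C(NCc1ccc(S(=O)(=O)c2ccccc2)cc1)NCc1cccnc1` gives the same 10000 nM. Together they hold the highest number of the three measured so far, while compound 2 `O=C(NCc1ccc(S(=O)(=O)c2ccccc2)cc1)c1cc2cnccc2[nH]1` gives 3000 nM.

The change to compound 4 `O=C(NCc1ccc(S(=O)(=O)C2CCC(F)(F)CC2)cc1)N1Cc2ccncc2C1` is 4,4-difluorocyclohexyl in place of 3-(trifluoromethyl)phenyl on a sulfonyl sulfur.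

Among the compounds with values here, only one measured step exists, a 3.3-fold lower number from compound 1 to compound 2 (0.52 log units; beyond the scatter). It was modest and beyond the scatter, but it sits on a carbonyl carbon, so it shows only how large a step can be here. Within the data shown here, no measured compound pair changes the group on the sulfonyl sulfur.

The estimated step in this assay, a 1.4-fold higher number from compound 3 to compound 4 (0.15 log units; within the scatter), is expected to stay within the scatter. Compound 4 is estimated at 14000 nM, within a range of 4000 nM to 50000 nM.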

Compound 4, solubility: 35000 nM
For compound 4 the middle estimate is 2.5-fold (0.40 log units) below the measured one; the range from low to high includes it.
By their numbers in this assay, from the lowest: compound 2; then compounds 1 and 3 (each within the scatter of the next); then compound 4.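

Within the data shown here, the first measured change on the sulfonyl sulfur, 4,4-difluorocyclohexyl in place of 3-(trifluoromethyl)phenyl, gives a 3.5-fold higher number from compound 3 to compound 4 (0.54 log units; beyond the scatter) in this assay. The group at this position can therefore shift the number beyond the scatter, and in this pair it goes up. Nothing measured here explains the rise.

As far as these compounds go, this single pair changes the ring and its fluorine substituents together, so their separate contributions stay open. Also open, from the compounds shown here alone, is how a piperidine ring or a butyl chain would read on the same sulfur.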